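The source may report more compounds than this note shows. Statements on the series, on what has been measured and on what is new or still open speak of the compounds shown alone.

Compound 1, `O=Cc1ccc(-c2cn3ccnc3c(-c3ccc4ncn(C5CCCCC5)c4c3)n2)cc1`, and compound 2, `O=Cc1ccc(-c2cn3ccnc3c(-c3ccc4ncn(Cc5ccccc5)c4c3)n2)cc1`, share one core and differ only in the group on the aromatic nitrogen: benzyl in place of cyclohexyl on an aromatic nitrogen. In a functional assay on SF-539 cells (Homo sapiens) for inhibition, read by sulforhodamine B assay, with a stated time of 48 h, tested at 10 uM (a lower number here means less inhibition, a higher number more inhibition at the concentration tested (going by the name of the read-out)), compound 1 gives 31.5%, and compound 2 gives 31.5%; the step of no change at the digits printed from compound 1 to compound 2 (within the scatter) is therefore flat. Compound 3, `c1cn2cc(-c3ccc4c(c3)ncn4C3CCCCC3)nc(-c3ccc4ncn(C5CCCCC5)c4c3)c2n1`, carries a second core whose difference from the core of compound 1 is not broken down here; in this assay compound 3 gives 35.7%, a number that lies within the scatter of both compound 1 and compound 2. Compound 4, `c1ccc(Cn2cnc3ccc(-c4nc(-c5ccc6c(c5)ncn6C5CCCCC5)cn5ccnc45)cc32)cc1`, has not yet been measured. It differs from compound 3 by the same change that turns compound 1 into compound 2, at the same place: benzyl in place of cyclohexyl on an aromatic nitrogen. Because the earlier instance of this change gave no change at the digits printed from compound 1 to compound 2 (within the scatter), the expected step in this assay is a number 0.7 percentage points lower from compound 3 to compound 4 (within the scatter), again a flat one. On that basis compound 4 is estimated at 35%, with an expected range from 22% to 48%.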

Compound 4, a percentage reported as inhibition, at one concentration (the size of the read-out at that concentration, not a potency): -77.6%
Compound 4: the middle estimate sits 112.6 percentage points above what was measured; the whole stated range lies above it.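

Benzyl in place of cyclohexyl on an aromatic nitrogen does not behave alike on both cores: in this assay it gives a number 113.3 percentage points lower from compound 3 to compound 4 (beyond the scatter). Set beside the flat step on the core of compound 1, this shows that the outcome of the change depends on the core carrying it, so a result on one core cannot simply be carried over to the other: the same change on two cores in this assay, no change at the digits printed (within the scatter) from compound 1 to compound 2 and a number 113.3 percentage points lower (beyond the scatter) from compound 3 to compound 4, 113.3 percentage points apart, beyond the scatter of two such steps

This comparison rests on one pair for each core, and it does not show which difference between the cores matters or why compound 4 gives -77.6%, a negative number on this read-out.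

The compounds shown leave open how a phenethyl group, a longer alkyl chain, or a chain ending in an amine or a carboxylic acid would behave at this aromatic nitrogen on either core. They also leave open whether the divergence between the two cores extends to cell lines other than the one in this assay.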